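The source may hold more compounds than are shown below. What is called first, only, known or untested is meant among the compounds shown, and "the series" means these compounds.

Working notes on the series. Of the compounds shown here, three of the shared core have been measured in a functional assay on HeLa cells (Homo sapiens) for antiproliferative activity, read by CCK-8 assay, with a stated time of 72 h, tested at 2 uM; a higher number here means a stronger effect of the compound at the concentration tested, a lower number a weaker effect. Compound 1 `Nc1ccccc1NC(=O)c1ccc(CSC(=S)N2CCN(c3ccccc3)CC2)cc1` gives 62.2% and stands highest of the three numbers. Compound 3 `CC1CCCCN1C(=S)SCc1ccc(C(=O)Nc2ccccc2N)cc1` gives 45.5%, a number below compound 1 by more than the scatter. Compound 2 `Nc1ccccc1NC(=O)c1ccc(CSC(=S)N2CCCc3ccccc32)cc1` gives 26.1%, the lowest number of the three and furthest from compound 1.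

Among the compounds with values here, the one step between measured compounds that differ in one place is on the thiocarbonyl carbon: a number 19.4 percentage points higher from compound 2 to compound 3 (beyond the scatter). It shows that the group on that end of the molecule can move the read-out in this assay by a modest amount.

Compound 4 `Nc1ccccc1NC(=O)c1ccc(CSC(=S)N2CCN(Cc3ccncc3)CC2)cc1` differs from compound 1 as follows: (pyridin-4-yl)methyl in place of phenyl on an amine nitrogen in a ring. Within the data shown here, no measured step touches the amine nitrogen in the ring, so none of the measured steps bears directly on this change; the step from compound 2 to compound 3 only sets the scale of what a change in this part of the molecule has done so far. A modest step downward, or none beyond the scatter, is expected. The change from compound 1 to compound 4 is expected to be a number 12.2 percentage points lower from compound 1 to compound 4 (beyond the scatter). Compound 4 is therefore estimated to give 50% in this assay, with an expected range from 30% to 70%.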

Compound 4, a percentage reported as inhibition, at one concentration (the size of the read-out at that concentration, not a potency): 59.5%
Estimate against measurement, compound 4: 9.5 percentage points below, and the stated range covers the measured number.
By their numbers in this assay, from the lowest: compound 2; then compound 3; then compounds 4 and 1 (each within the scatter of the next).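

Within the data shown here, the first measured change on the amine nitrogen in the ring gives, in this assay, a number 2.7 percentage points lower from compound 1 to compound 4 (within the scatter). At this position, therefore, (pyridin-4-yl)methyl can take the place of phenyl, bringing a ring nitrogen and a hydrogen-bond acceptor, without moving the read-out beyond the scatter; this holds for this one pair at the single tested concentration and does not compare potencies. No measurement at hand explains why the read-out holds across this change.

The compounds shown do not separate the contribution of the pyridine ring nitrogen from that of the methylene link, which benzyl on the same nitrogen would address. They also leave open whether this nitrogen needs an aromatic ring at all, a question that a simple methyl or an acetyl group there would test.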